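The source may hold more compounds than are shown below. What is called first, only, known or untested is meant among the compounds shown, and "the series" means these compounds.

Measured compounds:
compound 1, `CC(C)c1cc(-c2n[nH]c(=O)n2-c2cccc(C(=O)NCCCCCC(=O)NO)c2)c(O)cc1O`, 4600 nM
compound 2, `CC(C)c1cc(-c2n[nH]c(=O)n2-c2cccc(C(=O)NCCCC(=O)NO)c2)c(O)cc1O`, 4600 nM
compound 3, `CC(C)c1cc(-c2n[nH]c(=O)n2-c2ccc(C(=O)NCCCCCCCC(=O)NO)cc2)c(O)cc1O`, 4600 nM

Three hydroxamic acids were measured in a functional assay on HEL cells (Homo sapiens) for inhibition; on this read-out lower numbers stand for stronger inhibition and higher numbers for weaker inhibition. Compound 1 gives 4600 nM, compound 2 gives 4600 nM and compound 3 gives 4600 nM, so all three stand level at the digits reported, within the scatter of one another. Compound 1 and compound 2 share a core and differ in one place: hydroxycarbamoyl in place of 2-(hydroxycarbamoyl)ethyl on a saturated chain carbon, three bonds along the chain from an amide-type nitrogen. This change gave no change at the digits printed from compound 1 to compound 2 (within the scatter). Compound 3 rests on another core; the difference between the two cores is not broken down here, and the values of compound 1 and compound 3 show no separation.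

Compound 4, `CC(C)c1cc(-c2n[nH]c(=O)n2-c2ccc(C(=O)NCCCCCC(=O)NO)cc2)c(O)cc1O`, is not yet measured. It differs from compound 3 in one place: hydroxycarbamoyl in place of 2-(hydroxycarbamoyl)ethyl on a saturated chain carbon, five bonds along the chain from an amide-type nitrogen. Among the compounds with values here, this is the same kind of change as the one from compound 1 to compound 2, though the place is not the same word for word: there it sat three bonds along the chain from an amide-type nitrogen, here it sits five bonds along the chain from an amide-type nitrogen. Since the earlier step gave no change at the digits printed from compound 1 to compound 2 (within the scatter), the step from compound 3 to compound 4 in this assay is expected to be about no change at the digits printed from compound 3 to compound 4 (within the scatter), resting on that single precedent. Compound 4 is accordingly estimated at 4600 nM, with a range of 2000 nM to 10000 nM.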

Compound 4, half-maximal inhibitory concentration: 4600 nM
Beside the measured number, compound 4's estimate shows no gap at the digits printed, within the range that was stated.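

In this assay, putting hydroxycarbamoyl in place of 2-(hydroxycarbamoyl)ethyl gave no change at the digits printed from compound 3 to compound 4 (within the scatter), and the two readings of this change agree: the same change on two cores in this assay, no change at the digits printed (within the scatter) from compound 1 to compound 2 and no change at the digits printed (within the scatter) from compound 3 to compound 4, 1.0-fold (0.00 log units) apart, within the scatter of two such steps Within this series, then, the change carried from the core of compound 1 to the core of compound 3 with no separation in the read-out, once three bonds and once five bonds along the chain from an amide-type nitrogen. Within the data shown here, this does not show that the change is without effect in general, since each core supplies only one pair, and all four compounds stand level, so the agreement is between two steps that show no movement and says nothing about how a step of real size would carry from one core to another.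

The compounds shown leave open whether a longer chain than that of compound 3 would separate from the level these four share. They also leave open whether a carboxylic acid or a primary amide in place of the hydroxycarbamoyl end would do so on either core.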